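Moving from an aminopropyl chain to an aminophenyl arm

A few compounds are considered here, and "the series" means these few. Any claim that something is new, unique, unknown or untested is made for them only; others in the source may bear on it.

Compound 3 `CN(C)CCCNc1c(C(=O)NCc2ccc(F)cc2)nc(Br)c2cccnc12` stands alone among the three measured compounds in giving an actual number: in a functional assay on MDA-MB-435 cells (Homo sapiens) for cytotoxicity, read by MTT assay, with a stated time of 72 h (a higher number here means a weaker inhibitor, a lower number a stronger inhibitor), compound 3 gives 7000 nM. Compound 1 `CS(=O)(=O)Oc1c(C(=O)NCc2ccc(F)cc2)nc(Br)c2cccnc12` reaches only the limit > 20000 nM in this assay. Compound 2 `C[C@H](Nc1c(C(=O)NCc2ccc(F)cc2)nc(Br)c2cccnc12)c1ccccc1` likewise sits at the limit > 20000 nM. The steps of an at least 2.8-fold lower number from compound 1 to compound 3 (0.45 log units; beyond the scatter) and an at least 2.8-fold lower number from compound 2 to compound 3 (0.45 log units; beyond the scatter) are the only readable ones, and both favour compound 3. Compound 4 `Nc1cccc(Nc2c(C(=O)NCc3ccc(F)cc3)nc(Br)c3cccnc23)c1` differs from compound 3 by 3-aminophenyl in place of 3-(dimethylamino)propyl on a nitrogen on an aromatic ring. Compound 2, which carries a 1-phenylethyl on the same nitrogen, sits at the limit of > 20000 nM in this assay, at which 2 of the 3 values shown sit, so the return to an aromatic substituent is expected to weaken activity. Compound 4 is therefore estimated at 15000 nM, between 5000 nM and 40000 nM, a step of a 2.1-fold higher number from compound 3 to compound 4 (0.33 log units; beyond the scatter).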

Compound 4, half-maximal inhibitory concentration: 8000 nM
Estimate against measurement, compound 4: 1.9-fold (0.27 log units) above; the range from low to high includes it.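

In this assay, swapping the 3-(dimethylamino)propyl chain on this nitrogen for 3-aminophenyl gives a 1.1-fold higher number from compound 3 to compound 4 (0.06 log units; within the scatter), so a chain without a ring is not required for a readable value. With 3-aminophenyl, the record also shows an at least 2.5-fold lower number from compound 2 to compound 4 (0.39 log units; beyond the scatter) and an at least 2.5-fold lower number from compound 1 to compound 4 (0.39 log units; beyond the scatter), so compound 2 shows that not every ring-bearing group on this nitrogen gives a readable value. Both of these steps start from a limit, not a number: the limit of > 20000 nM in this assay, at which 2 of the 4 values shown sit.

From the compounds shown here alone, what a plain phenyl ring on this nitrogen would give remains open. So does the effect of a carboxylic acid on that ring or of a longer chain ending in dimethylamino.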